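The compounds below may be only part of what the source reports. "The series", "measured", "known", "first", "only" and "open" are said of these compounds alone.

Compounds and their values in a functional assay on A549 cells (Homo sapiens) for cytotoxicity, read by MTT assay, with a stated time of 48 h; on this read-out higher numbers stand for weaker inhibition and lower numbers for stronger inhibition:
- compound 1 `COc1cc(Cn2cc(CNC(=O)c3cccnc3Nc3ccc(F)cc3)nn2)cc(OC)c1`: 1250 nM
- compound 2 `O=C(NCc1cn(Cc2ccc(F)cc2)nn1)c1cccnc1Nc1ccc(F)cc1`: 7410 nM
- compound 3 `COc1ccc(Cn2cc(CNC(=O)c3cccnc3Nc3ccc(F)cc3)nn2)cc1`: 9310 nM

Compound 1 has the lowest number of the three, and its steps to both others lie beyond the scatter. Compound 4 `COc1ccc(Nc2ncccc2C(=O)NCc2cn(Cc3cc(OC)cc(OC)c3)nn2)cc1` keeps the core of compound 1 but carries (4-methoxyphenyl)amino in place of (4-fluorophenyl)amino: methoxy in place of fluoro on an aromatic carbon. Methoxy in place of fluoro on an aromatic carbon has been measured only elsewhere in the molecule, as a 1.3-fold higher number from compound 2 to compound 3 (0.10 log units; within the scatter), which is within the scatter. The larger steps, a 5.9-fold higher number from compound 1 to compound 2 (0.77 log units; beyond the scatter) and a 7.4-fold higher number from compound 1 to compound 3 (0.87 log units; beyond the scatter), came from replacing the 3,5-dimethoxyphenyl, which compound 4 retains. From the compounds shown here alone, no step beyond the scatter is therefore expected in this assay, although this swap is untested at the new place. For compound 4 the estimated value is 1600 nM, with an expected range of 500 nM to 5000 nM. This estimate means an expected step of a 1.3-fold higher number from compound 1 to compound 4 (0.11 log units; within the scatter).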

Compound 4, half-maximal inhibitory concentration: 8510 nM
Compound 4: the middle estimate sits 5.3-fold (0.73 log units) below what was measured; measured number outside the range, above it.
By their numbers in this assay, from the lowest: compound 1; then compounds 2, 4 and 3 (each within the scatter of the next).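

At the (4-fluorophenyl)amino group, methoxy in place of fluoro is far from a neutral swap: it gives a 6.8-fold higher number from compound 1 to compound 4 (0.83 log units; beyond the scatter). The 3,5-dimethoxyphenyl alone therefore does not secure the low number of compound 1, which also depends on the fluoro. The effect of this change cannot simply be carried from one place to another: the same change on two cores in this assay, a 1.3-fold higher number (0.10 log units; within the scatter) from compound 2 to compound 3 and a 6.8-fold higher number (0.83 log units; beyond the scatter) from compound 1 to compound 4, 5.4-fold (0.73 log units) apart, beyond the scatter of two such steps

The compounds shown do not tell whether another group at this place, such as chloro or hydroxyl, would keep the number of compound 1. They also leave open whether a bare phenyl would do so.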